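Swapping the anilide arm for a heptyl chain

The source may hold more compounds than are shown below. What is called first, only, known or untested is meant among the compounds shown, and "the series" means these compounds.

Compound 1 `CCOC(=O)C1=Cc2ccccc2OC1(OCc1cn(CC(=O)Nc2cccc(F)c2)nn1)C(F)(F)F` stands at the edge of what a functional assay on DU-145 cells (Homo sapiens) for inhibition, read by MTT assay, with a stated time of 24 h (a higher number here means a weaker inhibitor, a lower number a stronger inhibitor), can report. In this assay compound 1 gives > 150000 nM, which is a limit of the assay and not a number. Compound 2 `O=C(O)C1=Cc2ccccc2OC1(OCc1cc(-c2ccc([N+](=O)[O-])cc2)no1)C(F)(F)F` shares the core, and in this assay compound 2 gives 100000 nM. Compound 3 `CCCCCCCCn1cc(COC2(C(F)(F)F)Oc3ccccc3C=C2C(=O)OCC)nn1` keeps the core of compound 1 and differs in one place: heptyl in place of (3-fluorophenyl)carbamoyl on a saturated chain carbon bound to an aromatic nitrogen. For the measured compounds named here, no measured step of this kind exists, and compound 1 sits only at the limit (the limit of > 150000 nM in this assay, at which 1 of the 2 values shown sits), so the step is expected to be small and within the scatter. The step of an at least 1.2-fold lower number from compound 1 to compound 3 (0.09 log units; that floor lies within the scatter) is expected to be near nil. Compound 3 is estimated at 120000 nM, within 40000 nM to 300000 nM.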

Compound 3, half-maximal inhibitory concentration: > 150000 nM
Compound 3: only a limit was reported; the forecaster's own chance of this, stated with the estimate: 55%; at least 1.2-fold (0.09 log units) between middle value and limit.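

In this assay compound 3 gives > 150000 nM, which is a limit of the assay and not a number. For the compounds shown here, compound 1 also stands at a limit, so no step between compound 1 and compound 3 can be read. On these data alone, how far heptyl and (3-fluorophenyl)carbamoyl differ in this place stays open.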